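The compounds below may be only part of what the source reports. "The series", "measured", "known", "first", "only" and "open" are said of these compounds alone.

Measured in a physicochemical assay for solubility, in phosphate buffer, measured as kinetic solubility, at pH 7.4; a lower number here means a less soluble compound, a higher number a more soluble compound:
- Compound 1 `Cc1ccc(-c2nc(CN3CCC(C(=O)NCCCN4C[C@H](C)C[C@H](C)C4)CC3)c(C)o2)cc1`: > 69 ug/mL (a limit of the assay, not a number)
- Compound 2 `Cc1cccc(C)c1-c1nc(CN2CCC(C(=O)NCCCN3C[C@H](C)C[C@H](C)C3)CC2)c(C)o1`: 55.9 ug/mL

Among the measured compounds shown here, compound 2, at 55.9 ug/mL, holds the only true number so far. The other reading is the limit of > 69 ug/mL in this assay, at which 1 of the 2 values shown sits, so it gives no exact reference point. Compound 3 `COc1cccc(OC)c1-c1nc(CN2CCC(C(=O)NCCCN3C[C@H](C)C[C@H](C)C3)CC2)c(C)o1` follows from compound 2 by one change: 2,6-dimethoxyphenyl in place of 2,6-dimethylphenyl on an aromatic carbon. For the measured compounds named here, the sole measured step, an at least 1.2-fold lower number from compound 1 to compound 2 (0.09 log units; that floor lies within the scatter), also exchanges the phenyl group on an aromatic carbon, and its floor lies within the scatter. Going by the values given here, no measured step exchanges methyl for methoxy, so this evidence is thin. In this assay, no step beyond the scatter is expected, and no direction is favoured, with compound 2 at 55.9 ug/mL as the anchor. The expected step is a 1.1-fold higher number from compound 2 to compound 3 (0.03 log units; within the scatter). For compound 3 the estimated value is 60 ug/mL, with an expected range of 35 ug/mL to 80 ug/mL.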

Compound 3, solubility: > 76 ug/mL
Compound 3: no number, only a limit (the forecaster's own chance of this, stated with the estimate: 35%); middle value at least 1.2-fold (0.10 log units) from the limit.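

In this assay, 2,6-dimethoxyphenyl in place of 2,6-dimethylphenyl on this aromatic carbon gives an at least 1.3-fold higher number from compound 2 to compound 3 (0.13 log units; that floor lies within the scatter). This is the first change shown that exchanges only the two groups on the phenyl group, and the true size of the step remains unknown. Compound 3 gives a limit, not a number: the limit of > 76 ug/mL in this assay, at which 1 of the 3 values shown sits.

The step from compound 1 to compound 3 cannot be read, so 4-methylphenyl and 2,6-dimethoxyphenyl cannot be placed in order on this carbon. Also open, going by these compounds, is what an amine or a carboxylic acid on the phenyl group would give in this assay, and whether the same change would hold with a longer chain in place of the propyl linker of the shared core.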